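Lengthening the fluorinated side chain of compound 3

The source may report more compounds than this note shows. Statements on the series, on what has been measured and on what is new or still open speak of the compounds shown alone.

Among the measured compounds shown here, compound 3 `COc1cc(C(=O)NS(=O)(=O)c2ccccc2C)ccc1Cc1cn(C)c2ccc(C(=O)NCC(C)C(F)(F)F)cc12` gives 5.89 in a physicochemical assay for lipophilicity (a higher number here means a more lipophilic compound, a lower number a more polar compound), the highest of the three numbers measured so far. Compound 1 `CCC(C)CNC(=O)c1ccc2c(c1)c(Cc1ccc(C(=O)NS(=O)(=O)c3ccccc3C)cc1OC)cn2C` stands nearest to it with 5.85, a gap that lies within the usual scatter. Compound 2 `CCC(CNC(=O)c1ccc2c(c1)c(Cc1ccc(C(=O)O)cc1OC)cn2C)CC(F)(F)F` stands furthest away with 5.53, beyond the scatter. For the measured compounds named here, only one measured step fits the comparison: a number 0.04 log units higher from compound 1 to compound 3 (within the scatter), a change that made no difference beyond the scatter.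

Compound 4 `COc1cc(C(=O)NS(=O)(=O)c2ccccc2C)ccc1Cc1cn(C)c2ccc(C(=O)NCC(C)CC(F)(F)F)cc12` has not yet been measured. It differs from compound 3 in one place: 2,2,2-trifluoroethyl in place of trifluoromethyl on a saturated chain carbon bound to two saturated chain carbons. Going by the values given here, no measured step lengthens a chain in this way, so the single step that bears on the question, from compound 1 to compound 3, only shows that swapping the end group of this chain left the partition coefficient essentially unchanged. A step of modest size upward is nonetheless expected for compound 4, namely a number 0.26 log units higher from compound 3 to compound 4 (within the scatter), giving an estimated 6.15 with an expected range from 5.75 to 6.55.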

Compound 4, partition coefficient: 6.18
Compound 4: middle estimate off by 0.03 log units, on the low side, within the range that was stated.
By their numbers in this assay, from the lowest: compound 2; then compounds 1, 3 and 4 (each within the scatter of the next, the first and the last beyond it).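

Putting 2,2,2-trifluoroethyl in place of trifluoromethyl on a saturated chain carbon bound to two saturated chain carbons gives, in this assay, a number 0.29 log units higher from compound 3 to compound 4 (within the scatter), so this single lengthening cannot be told apart from repeat measurement on its own. Read against the chain carrying methyl, however, putting trifluoromethyl in place of methyl on a saturated chain carbon, three bonds along the chain from an amide-type nitrogen, gives a number 0.33 log units higher from compound 1 to compound 4 (beyond the scatter), the first step at this place to clear the scatter, though only modestly. Nothing available explains why these numbers fall as they do.

On these data alone, whether propyl at this same place would read like compound 4 stays open, so the share of the fluorine atoms and the share of chain length remain unseparated. Also open, as far as these compounds go, is how a chain ending in an amine or a hydroxyl group would read here.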